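The compounds below may be only part of what the source reports. "The series", "measured", "known", "first", "only" and "open" are said of these compounds alone.

Of the compounds shown here, three have been read so far in an ADME assay on HepG2 cells (Homo sapiens) for cytotoxicity, with a stated time of 72 h (a higher number here means that more compound is needed for the effect, a lower number that less compound is needed), and none of them has given a number. Compound 1 `O=C(Nc1ccc(-c2nc3ccccc3s2)cc1)c1cc([N+](=O)[O-])ccc1Cl` gives > 27000 nM, which is a limit of the assay. Compound 2 `O=C(Nc1ccc(Cl)c(-c2nc3ccccc3s2)c1)c1cc([N+](=O)[O-])ccc1Cl` gives > 25000 nM, which is also a limit. Compound 3 `O=C(Nc1ccc(Cl)c(C(F)(F)F)c1)c1cc([N+](=O)[O-])ccc1Cl` gives > 27000 nM, again a limit, so it has no exact position on the scale. Compound 4 `O=C(Nc1ccc(Cl)cc1)c1cc([N+](=O)[O-])ccc1Cl` comes from compound 3 by a single change: hydrogen in place of trifluoromethyl on an aromatic carbon. The change removes trifluoromethyl and leaves hydrogen on that aromatic carbon. Going by the values given here, the one measured step at this place is a step that the two limits leave unreadable from compound 2 to compound 3. That step offers no size to carry over, so no step beyond the scatter is expected in this assay, and compound 4 is expected to report a limit as well. The estimate for compound 4 is 30000 nM, with an expected range from 12000 nM to 70000 nM. The expected step is a step that the limit leaves unreadable from compound 3 to compound 4.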

Compound 4, half-maximal effective concentration: > 27000 nM
Compound 4 gave a limit, no number (the forecaster's own chance of this, stated with the estimate: 75%); the middle value is on the limit's open side.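

Compound 4, like compounds 1, 2 and 3, ends at a limit and not a number, so its steps from those three compounds cannot be read. The compounds shown leave open where any of the four would give an actual number in this assay.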